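Benzyl ether variation on the pyridinyl salicylamide series

This account rests on a few compounds, and the source may have more. Where it says the series, first, only, none or still open, it means among the compounds named here.

Measured so far:
compound 1, `O=C(Nc1cccnc1)c1ccccc1OCc1ccccc1Cl`, 1100 nM
compound 2, `Cc1ccc(Cl)cc1COc1ccccc1C(=O)Nc1cccnc1`, 1100 nM

Both compounds share the same core and differ only in the aryl group on the saturated chain carbon bound to an oxygen on the aromatic ring. In an assay on lysate for inhibition of phosphatidylcholine:ceramide cholinephosphotransferase 2 (Homo sapiens), read by HPLC, with stated times of 30 min and 2 h (on this read-out higher numbers stand for weaker inhibition and lower numbers for stronger inhibition), compound 1 gives 1100 nM, and compound 2 gives 1100 nM in this assay. Among the measured compounds shown here, the single step measured, no change at the digits printed from compound 1 to compound 2 (within the scatter), shows that exchanging one chlorinated aryl group for another leaves the read-out level within the scatter. On the numbers shown, compound 2 therefore stands level with compound 1.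

Compound 3, `Cc1cccc(C)c1COc1ccccc1C(=O)Nc1cccnc1`, is not yet measured in this assay. It differs from compound 2 as follows: 2,6-dimethylphenyl in place of 5-chloro-2-methylphenyl on a saturated chain carbon bound to an oxygen on an aromatic ring. For the measured compounds named here, the only step that bears on this change is no change at the digits printed from compound 1 to compound 2 (within the scatter), which was flat; no measured step separates a chlorine from a methyl on this pendant ring, so nothing here points to a shift in either direction. Compound 3 is expected to stay level with compound 2, the estimated step being a 1.1-fold higher number from compound 2 to compound 3 (0.04 log units; within the scatter). The estimate for compound 3 in this assay is 1200 nM, with a range from 500 nM to 3000 nM.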

Compound 3, half-maximal inhibitory concentration: 890 nM
The estimate for compound 3 lay 1.3-fold (0.13 log units) above the measured number; the range from low to high includes it.
By their numbers in this assay, from the lowest: compounds 3, 1 and 2 (each within the scatter of the next).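

In this assay, 2,6-dimethylphenyl in place of 5-chloro-2-methylphenyl on the saturated chain carbon bound to an oxygen on an aromatic ring gives a 1.2-fold lower number from compound 2 to compound 3 (0.09 log units; within the scatter), and 2,6-dimethylphenyl in place of 2-chlorophenyl gives a 1.2-fold lower number from compound 1 to compound 3 (0.09 log units; within the scatter). The earlier step compared only chlorine-bearing aryl groups, whereas the entering group here has 8 carbon atoms and no chlorine, so among these compounds the presence of chlorine on the pendant ring is not needed to keep the read-out within the scatter, and all three aryl groups remain level. No measurement is available that could explain this flat result at the position.

Going by these compounds, all the aryl groups compared here carry only chlorine or methyl and have no hydrogen-bond donors or acceptors, so it remains open whether an amine or a carboxylic acid on the pendant ring would move the number beyond the scatter. Among the compounds shown here, also open is whether a longer chain in place of the single saturated carbon bound to the oxygen would do so, since no step in this set yet lies beyond the scatter.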